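This account rests on a few compounds, and the source may have more. Where it says the series, first, only, none or still open, it means among the compounds named here.

The compounds share one core. Compound 1 `Nc1nn2c(O)cc(-c3ccccc3)nc2c1[N+](=O)[O-]` and compound 2 `Nc1nn2c(O)cc(-c3ccc(F)cc3)nc2c1[N+](=O)[O-]` carry a phenyl or a 4-fluorophenyl on that core. In a functional assay on L929 cells (Mus musculus) for inhibition (on this read-out lower numbers stand for stronger inhibition of growth and higher numbers for weaker inhibition of growth), compound 1 reaches only a limit of the assay, > 50 ug/mL. Compound 2 likewise gives a limit, > 50 ug/mL. Within the data shown here, compound 3 `NNCc1cc(O)n2nc(N)c([N+](=O)[O-])c2n1` carries an (aminoamino)methyl group instead, and in this assay compound 3 gives 35.2 ug/mL, the only real number among the three results. The change from compound 1 to compound 3 gives an at least 1.4-fold lower number from compound 1 to compound 3 (0.15 log units; that floor lies within the scatter), and from compound 2 to compound 3 an at least 1.4-fold lower number from compound 2 to compound 3 (0.15 log units; that floor lies within the scatter); both floors rest on (the limit of > 50 ug/mL in this assay, at which 2 of the 3 values shown sit). The step from compound 1 to compound 2 is a step that the two limits leave unreadable from compound 1 to compound 2. Compound 4 `COc1ccc(NNCc2cc(O)n3nc(N)c([N+](=O)[O-])c3n2)cc1` differs from compound 3 by 4-methoxyphenyl in place of hydrogen on an amine nitrogen. Among the measured compounds shown here, no measured step touches this nitrogen, so the earlier steps give no direct guide; the expected step from compound 3 to compound 4 in this assay is therefore a 1.2-fold lower number from compound 3 to compound 4 (0.07 log units; within the scatter), not clearly beyond the scatter. Compound 4 is estimated to give 30 ug/mL, between 8 ug/mL and 80 ug/mL.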

Compound 4, concentration for 50% growth inhibition: > 50 ug/mL
Compound 4 gave a limit, no number; the forecaster's own chance of this, stated with the estimate: 30%; middle value at least 1.6-fold (0.22 log units) from the limit.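

Among these compounds, until now, the only readable change lay on an aromatic carbon of the shared core, where the (aminoamino)methyl group replaced an aromatic ring; this result is the first reading on an amine nitrogen of that group. In this assay, 4-methoxyphenyl in place of hydrogen on that nitrogen gives an at least 1.4-fold higher number from compound 3 to compound 4 (0.15 log units; that floor lies within the scatter), so the step points towards weaker inhibition of growth, but its floor does not clear the usual scatter. Its full size cannot be read because compound 4 also sits at a limit of the assay: the limit of > 50 ug/mL in this assay, at which 3 of the 4 values shown sit.

The compounds shown leave open whether a small group on this nitrogen, such as methyl or acetyl, would keep, lower or raise the value of compound 3, 35.2 ug/mL. They also leave open whether a plain phenyl there would behave as 4-methoxyphenyl does.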